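The source may report more compounds than this note shows. Statements on the series, on what has been measured and on what is new or still open speak of the compounds shown alone.

Values in an assay on isolated protein for inhibition of lysosomal alpha-glucosidase (Rattus norvegicus), read by spectrophotometry, with a stated time of 5 min; a higher number here means a weaker inhibitor, a lower number a stronger inhibitor:

- compound 1 `O=C(/C=C/c1ccc(O)cc1)c1ccc2occc2c1O`: 10900 nM
- compound 2 `O=C(/C=C/c1ccc(O)c(O)c1)c1ccc2occc2c1O`: 15200 nM
- compound 3 `COc1ccc(/C=C/C(=O)c2ccc3occc3c2O)c(OC)c1OC`: 17300 nM

Compound 1 carries the smallest of the three numbers, but its gaps to compound 2 and to compound 3 both lie within the scatter, so the three are not separated. Among the measured compounds shown here, the only single-point step recorded is a 1.4-fold higher number from compound 1 to compound 2 (0.14 log units; within the scatter), a hydroxy added on an aromatic carbon, which left the number essentially unchanged. Compound 4 `COc1ccc(/C=C/C(=O)c2ccc3occc3c2O)cc1` differs from compound 1 by methyl in place of hydrogen on an oxygen on an aromatic ring. For the measured compounds named here, no measured step covers this hydroxy-to-methoxy change; compound 3, which carries three methoxy groups, only shows a value close to compound 1. With all known steps inside the scatter, the expected step of a 1.1-fold higher number from compound 1 to compound 4 (0.02 log units; within the scatter) is none beyond the scatter. Compound 4 is therefore estimated at 11500 nM, range 5500 nM to 25000 nM.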

Compound 4, half-maximal inhibitory concentration: 9200 nM
Compound 4: middle estimate off by 1.3-fold (0.10 log units), on the high side; low and high end bracket the measured number.
By their numbers in this assay, from the lowest: compounds 4, 1, 2 and 3 (each within the scatter of the next).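

Methyl in place of hydrogen on the oxygen on the aromatic ring gives a 1.2-fold lower number from compound 1 to compound 4 (0.07 log units; within the scatter) in this assay, the first direct reading of hydroxy to methoxy in this series. The free hydroxy at this place is therefore not required for a number in this range, and a methyl on that oxygen is tolerated. No available data explain this result.

Still open, going by these compounds, is whether a longer chain, a benzyl group or a chain ending in an amine or a carboxylic acid on this oxygen would move the number beyond the scatter.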